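Swapping the ring-nitrogen substituent: from pyridinylmethyl to fluorophenyl

The source may hold more compounds than are shown below. What is called first, only, known or untested is meant among the compounds shown, and "the series" means these compounds.

Of the compounds shown here, three sharing one core have been tested in a functional assay on HeLa cells (Homo sapiens) for antiproliferative activity, read by CCK-8 assay, with a stated time of 72 h, tested at 2 uM; a higher number here means a stronger effect of the compound at the concentration tested, a lower number a weaker effect. Compound 1 `Nc1ccccc1NC(=O)c1ccc(CSC(=S)N2CCN(c3ccccc3)CC2)cc1` gives 62.2%, compound 2 `Cc1ccc(N2CCN(C(=S)SCc3ccc(C(=O)Nc4ccccc4N)cc3)CC2)cc1` gives 25.3%, and compound 3 `Nc1ccccc1NC(=O)c1ccc(CSC(=S)N2CCN(Cc3cccnc3)CC2)cc1` gives 69.7%. Compound 3 has the highest of the three numbers, but the step of a number 7.5 percentage points higher from compound 1 to compound 3 (within the scatter) means that these two cannot be ordered; the step of a number 44.4 percentage points higher from compound 2 to compound 3 (beyond the scatter), by contrast, is a clear separation.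

Compound 4 `Nc1ccccc1NC(=O)c1ccc(CSC(=S)N2CCN(c3ccccc3F)CC2)cc1` has not yet been measured. It differs from compound 3 in one place: 2-fluorophenyl in place of (pyridin-3-yl)methyl on an amine nitrogen in a ring.

Within the data shown here, the steps that bear on this change are a number 7.5 percentage points higher from compound 1 to compound 3 (within the scatter), showing that phenyl and (pyridin-3-yl)methyl on that ring nitrogen give much the same number, and a number 36.9 percentage points lower from compound 1 to compound 2 (beyond the scatter), showing that adding a methyl to the phenyl cut the inhibition sharply. A fluorine on the phenyl is a different substituent in a different place, so this step is expected to be small, likely a modest drop of a number 14.7 percentage points lower from compound 3 to compound 4 (beyond the scatter). Compound 4 is therefore estimated at 55%, within a range from 30% to 75%.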

Compound 4, a percentage reported as inhibition, at one concentration (the size of the read-out at that concentration, not a potency): 17.5%
Compound 4: middle estimate off by 37.5 percentage points, on the high side, outside the stated range (below it).
By their numbers in this assay, from the lowest: compounds 4 and 2 (each within the scatter of the next); then compounds 1 and 3 (each within the scatter of the next).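

In this assay, adding a single fluoro to the phenyl on the ring nitrogen is enough to change the result (a number 44.7 percentage points lower from compound 1 to compound 4 (beyond the scatter)), so even a small addition to that phenyl cannot be assumed harmless. Replacing the (pyridin-3-yl)methyl group gives a step of similar scale (a number 52.2 percentage points lower from compound 3 to compound 4 (beyond the scatter)), while the 2-fluorophenyl and 4-methylphenyl compounds cannot be told apart (a number 7.8 percentage points lower from compound 2 to compound 4 (within the scatter)), so both substituted phenyls shown give low numbers despite carrying different groups in different places. Nothing measured here explains why these additions to the phenyl have this effect.

The compounds shown leave open whether the outcome depends on where the group sits on the phenyl, and whether a chloro or methoxy group would behave the same way. They also leave open whether a plain benzyl group on the ring nitrogen would give a number close to that of compound 3.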